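This account rests on a few compounds, and the source may have more. Where it says the series, first, only, none or still open, it means among the compounds named here.

The measured compounds in a functional assay on CHO cells for antagonist activity at prostaglandin E2 receptor EP3 subtype (Homo sapiens), read by cAMP accumulation; on this read-out lower numbers stand for stronger inhibition and higher numbers for weaker inhibition:
compound 1, `CC(C)C(Nc1nnc[nH]1)c1ccc(-c2ccc3cccc(F)c3c2)[nH]c1=O`, 185 nM
compound 2, `CCn1ncc2c(F)cc(-c3ccc(C(CC)(CC)c4nnc(C)[nH]4)c(=O)[nH]3)cc21`, 90 nM
compound 3, `Cc1nc(C(c2ccc(-c3ccc4cccc(F)c4c3)[nH]c2=O)C(C)C)[nH]c1C`, 50 nM

Compound 3 has the lowest number of the three. Compound 2 stands nearest to it, and the two lie within the scatter of each other, so no order between them can be claimed. Compound 1 stands furthest away, and the step of a 3.7-fold lower number from compound 1 to compound 3 (0.57 log units; beyond the scatter) lies beyond the scatter. Compound 2 differs from the others at more than one place, so its value cannot be tied to a single change.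

Compound 4, `CC(C)C(Cc1nnn[nH]1)c1ccc(-c2ccc3cccc(F)c3c2)[nH]c1=O`, differs from compound 3 by (1H-tetrazol-5-yl)methyl in place of 4,5-dimethyl-1H-imidazol-2-yl on a saturated chain carbon bound to an aromatic carbon and a saturated chain carbon. For the measured compounds named here, the only measured step that bears on this carbon is a 3.7-fold lower number from compound 1 to compound 3 (0.57 log units; beyond the scatter): exchanging the group there shifted the number by a modest amount. Going by the values given here, no measured compound carries the entering group, so the direction for compound 4 rests on that single step alone. Since the group of compound 3 gave the lowest number seen, a further exchange at the same carbon is expected to raise the number rather than lower it, by a step of about the size already observed.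

For compound 4 in this assay a value of 150 nM is estimated, with a range from 40 nM to 600 nM. This estimate means an expected step of a 3.0-fold higher number from compound 3 to compound 4 (0.48 log units; beyond the scatter).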

Compound 4, half-maximal inhibitory concentration: 134 nM
Compound 4: middle estimate off by 1.1-fold (0.05 log units), on the high side, within the range that was stated.
By their numbers in this assay, from the lowest: compounds 3, 2, 4 and 1 (each within the scatter of the next, the first and the last beyond it).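

In this assay, the saturated chain carbon bound to an aromatic carbon now carries a third group, and a 2.7-fold higher number from compound 3 to compound 4 (0.43 log units; beyond the scatter) shows that the number reached with 4,5-dimethyl-1H-imidazol-2-yl does not hold when (1H-tetrazol-5-yl)methyl enters there. The other new comparison, a 1.4-fold lower number from compound 1 to compound 4 (0.14 log units; within the scatter), leaves (1H-tetrazol-5-yl)methyl and (4H-1,2,4-triazol-3-yl)amino level, so that of the three groups at this carbon only 4,5-dimethyl-1H-imidazol-2-yl stands apart, with its steps to both others beyond the scatter. Nothing among the data shown gives a reason for this difference.

The compounds shown leave open whether the lower number of compound 3 belongs to the imidazole ring itself or to its two methyl groups, which a plain 1H-imidazol-2-yl would separate. They also say nothing of how a carboxylic acid, an amine or a longer chain ending in the tetrazole would behave on this carbon, or whether the order among these groups would hold on the different core of compound 2.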